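This account rests on a few compounds, and the source may have more. Where it says the series, first, only, none or still open, it means among the compounds named here.

Measured so far:
- compound 1, `O=C(O)[C@@H]1NC[C@@H](O)[C@@H](O)[C@H]1O`: 8.2%
- compound 2, `O=C(O)[C@H]1NC[C@H](O)[C@@H](O)[C@H]1O`: 31%
- compound 3, `O=C(O)[C@H]1NC[C@@H](O)[C@H](O)[C@@H]1O`: 11%

In an assay for inhibition of alpha-N-acetylgalactosaminidase (Gallus gallus), tested at 1000 uM (on this read-out higher numbers stand for more inhibition at the one concentration tested (going by the name of the read-out) and lower numbers for less inhibition), compound 3 stands second highest of the three numbers, though its gap to compound 1 is within the scatter: the step of a number 2.8 percentage points higher from compound 1 to compound 3 (within the scatter). Among the measured compounds shown here, the one step that is beyond the scatter among the measured pairs involving compound 3 is a number 20 percentage points lower from compound 2 to compound 3 (beyond the scatter), and the other measured step in the set is a number 22.8 percentage points higher from compound 1 to compound 2 (beyond the scatter); both rest only on changes of configuration, (the fact that compounds 1 and 2 differ only in the configuration as drawn), the fact that compounds 1 and 3 differ only in the configuration as drawn and (the fact that compounds 2 and 3 differ only in the configuration as drawn).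

Compound 4, `O=C(O)[C@@H]1NC[C@@H](O)[C@H](O)[C@H]1O`, is not yet measured. Relative to compound 3 the change is the two compounds have the same atoms and bonds and differ only in configuration as drawn: 2 of 4 stereo elements differ; a stereocentre at a saturated ring carbon is drawn S in compound 3 and R in compound 4; a stereocentre at a saturated ring carbon is drawn R in compound 3 and S in compound 4. For the measured compounds named here, no measured step connects compound 4 to any measured compound directly, so the expectation rests on the spread among the three stereoisomers already in hand: configuration changes of this kind have moved the read-out by a modest amount in either direction, or not beyond the scatter. The step from compound 3 is expected to be small, a number 4 percentage points higher from compound 3 to compound 4 (within the scatter), with wide uncertainty. Compound 4 is estimated at 15%, in the range 4% to 35%.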

Compound 4, a percentage reported as inhibition, at one concentration (the size of the read-out at that concentration, not a potency): 1.3%
Compound 4: the middle estimate sits 13.7 percentage points above what was measured; the measured number lies below the stated range.
By their numbers in this assay, from the lowest: compounds 4, 1 and 3 (each within the scatter of the next); then compound 2.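

In this assay, the smallest change in configuration in the set, a single stereocentre at a saturated ring carbon, gives a number 6.9 percentage points lower from compound 1 to compound 4 (within the scatter). The two-centre change gives a number 9.7 percentage points lower from compound 3 to compound 4 (within the scatter), so compounds 1, 3 and 4 are not separated by this read-out, whether one centre or two differ. Compound 2 alone stands apart, now against a third isomer, with a number 29.7 percentage points lower from compound 2 to compound 4 (beyond the scatter), the widest step in the set, and every step here rests on configuration only: the fact that compounds 2 and 4 differ only in the configuration as drawn

Which of the centres that differ in compound 2 carries its gap stays open, since no compound shown changes one of them alone from compound 2. Also open, going by these compounds, is whether the configuration of compound 2 keeps its gap when the carboxylic acid gives way to a hydroxymethyl group or an amide.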